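Removing the ring fluorine from a weak pyrimidine carboxamide

The source may report more compounds than this note shows. Statements on the series, on what has been measured and on what is new or still open speak of the compounds shown alone.

The study measures cytotoxicity in a functional assay on MCF7 cells (Homo sapiens) for cytotoxicity, read by MTT assay, with a stated time of 72 h; a higher number here means a weaker inhibitor, a lower number a stronger inhibitor. Compound 1, `CNC(=O)c1cc(Oc2ccc(NC(=O)c3cc(-c4ccc(F)cc4)ncn3)cc2F)ccn1`, sits at the limit of this assay, giving > 100000 nM, which is a limit and not a number. Compound 2, `CNC(=O)c1cc(Oc2ccc(NC(=O)c3cc(-c4ccc(OC)cc4)ncn3)cc2F)ccn1`, gives 46200 nM in this assay. The change from compound 1 to compound 2 is an at least 2.1-fold lower number from compound 1 to compound 2 (0.33 log units; beyond the scatter). Compound 3, `CNC(=O)c1cc(Oc2ccc(NC(=O)c3nccc(-c4cccc(Cl)c4)n3)cc2)ccn1`, also stands at the limit of this assay with > 100000 nM. Thus (the limit of > 100000 nM in this assay, at which 2 of the 3 values shown sit). The next compound, compound 4, `CNC(=O)c1cc(Oc2ccc(NC(=O)c3cc(-c4ccc(F)cc4)ncn3)cc2)ccn1`, differs from compound 1 in one place: hydrogen in place of fluoro on an aromatic carbon. Among the compounds with values here, no measured step in this set concerns a hydrogen in place of fluoro, so the only direct evidence is that compound 1 lies at the limit, and compound 3, which also lacks a fluoro on the same ring, shows only a limit as well. The step for compound 4 is therefore expected to be a number no higher from compound 1 to compound 4 (the limit leaves the size open), with no clear direction beyond the scatter. Compound 4 is estimated to give 100000 nM in this assay, between 30000 nM and 400000 nM.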

Compound 4, half-maximal inhibitory concentration: > 100000 nM
Compound 4: a limit, no number; the forecaster's own chance of this, stated with the estimate: 60%; the middle value lies on the limit itself.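

In this assay compound 4 gives > 100000 nM, which is a limit and not a number. Compound 1 also stands at a limit, so no step can be read between compound 1 and compound 4: the limit of > 100000 nM in this assay, at which 3 of the 4 values shown sit. The compounds shown leave open whether hydrogen in place of fluoro changes the read-out at all.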